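Benzylamine variation on a bis(trifluoromethyl)benzenesulfonamide series

The compounds below may be only part of what the source reports. "The series", "measured", "known", "first", "only" and "open" are said of these compounds alone.

Going by the values given here, compound 2 `O=S(=O)(NCCCNCc1ccc(Br)cc1)c1cc(C(F)(F)F)cc(C(F)(F)F)c1` is measured in a functional assay on A2780 cells (Homo sapiens) for inhibition, read by MTT assay, with a stated time of 72 h (a lower number here means a stronger inhibitor of growth, a higher number a weaker inhibitor of growth), at 2600 nM, the lowest of the two numbers so far, though only within the scatter of compound 1 `O=S(=O)(NCCCNCc1ccc(C(F)(F)F)cc1)c1cc(C(F)(F)F)cc(C(F)(F)F)c1`, which in this assay gives 2800 nM. Among the compounds with values here, the one step at hand, a 1.1-fold lower number from compound 1 to compound 2 (0.03 log units; within the scatter), shows no effect beyond the scatter. Compound 3 `O=S(=O)(NCCCNCc1cccc(Cl)c1)c1cc(C(F)(F)F)cc(C(F)(F)F)c1` differs from compound 2 by 3-chlorophenyl in place of 4-bromophenyl on a saturated chain carbon bound to an amine nitrogen. Both the halogen and its position on the ring change at once; the measured step speaks only to a change of the group at one position and says nothing about a moved substituent. Given that the swap from trifluoromethyl to bromo left the number untouched, the expectation for compound 3 is a step of a 1.2-fold higher number from compound 2 to compound 3 (0.06 log units; within the scatter), no larger than the scatter. The estimated value for compound 3 in this assay is 3000 nM, within 1200 nM to 8000 nM.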

Compound 3, concentration for 50% growth inhibition: 2200 nM
Beside the measured number, compound 3's estimate is 1.4-fold (0.13 log units) above it; the measured number falls inside the stated range.
By their numbers in this assay, from the lowest: compounds 3, 2 and 1 (each within the scatter of the next).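

In this assay, 3-chlorophenyl in place of 4-bromophenyl gives a 1.2-fold lower number from compound 2 to compound 3 (0.07 log units; within the scatter), and 3-chlorophenyl in place of 4-(trifluoromethyl)phenyl gives a 1.3-fold lower number from compound 1 to compound 3 (0.10 log units; within the scatter). The earlier step changed only the group at one ring position, whereas these steps change the group and its ring position together, and still no difference beyond the scatter appears among the three aryl groups at this place. Nothing on hand accounts for this flat result.

The separate contributions of the halogen and its ring position remain unresolved, and 3-bromophenyl would address that directly. Also open, on these data alone, is whether an amine or a carboxylic acid on the phenyl ring, or a longer chain in the shared core, would shift the number beyond the scatter.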